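The compounds below may be only part of what the source reports. "The series", "measured", "known", "first", "only" and "open" are said of these compounds alone.

Measured compounds:
compound 1 `CCOC(=O)c1cn(Cc2nnc(-c3cc(S(N)(=O)=O)c(SCc4ccccc4)cc3Cl)o2)nn1` gives 0.085 h
compound 2 `NS(=O)(=O)c1cc(-c2nnc(CNC(=O)c3ccccc3)o2)c(Cl)cc1SCc1ccccc1` gives 0.187 h

Both were measured in an ADME assay on microsomes from liver (Homo sapiens) for metabolic stability, read by LC-MS, using NADPH, tested at 5 uM; on this read-out higher numbers stand for a longer-lived compound and lower numbers for a shorter-lived compound. Among the measured compounds shown here, compound 2 holds the higher of the two numbers; its only neighbour is compound 1, and the step of a 2.2-fold higher number from compound 1 to compound 2 (0.34 log units; beyond the scatter) sets the two apart beyond the usual scatter of this assay. Compound 3 `NS(=O)(=O)c1cc(-c2nnc(CNS(=O)(=O)c3ccc(Cl)cc3)o2)c(Cl)cc1SCc1ccccc1` is the next compound in this line and has not yet been measured. It differs from compound 2 in one place: (4-chlorophenyl)sulfonyl in place of benzoyl on an amine nitrogen. For the measured compounds named here, the single measured step, a 2.2-fold higher number from compound 1 to compound 2 (0.34 log units; beyond the scatter), changed a different group at the same chain carbon, so it does not speak directly to an exchange of benzoyl for (4-chlorophenyl)sulfonyl on that nitrogen, and no other measured pair covers it. On that basis the expected step is a 1.1-fold higher number from compound 2 to compound 3 (0.03 log units; within the scatter), not beyond the scatter in either direction. Compound 3 is therefore estimated at 0.2 h, with a range from 0.08 h to 0.5 h.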

Compound 3, half-life: 0.197 h
Compound 3: the middle estimate sits 1.0-fold (0.01 log units) above what was measured; measured number inside the range.
By their numbers in this assay, from the lowest: compound 1; then compounds 2 and 3 (each within the scatter of the next).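

On an amine nitrogen, (4-chlorophenyl)sulfonyl in place of benzoyl gives a 1.1-fold higher number from compound 2 to compound 3 (0.02 log units; within the scatter) in this assay, so this exchange leaves the half-life within the usual scatter even though the group entering is larger and carries a sulfur and a chlorine. The second listed change, ((4-chlorophenyl)sulfonyl)amino in place of 4-(ethoxycarbonyl)-1H-1,2,3-triazol-1-yl on the saturated chain carbon, gives a 2.3-fold higher number from compound 1 to compound 3 (0.37 log units; beyond the scatter), which matches the size of the earlier step from that triazole to benzamido. Among these three compounds, then, both groups joined through the amine nitrogen stand above the triazole, and none goes against this; no measurement here offers an explanation for it.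

The swap alters the linking group and adds the chlorine at once, so a plain phenylsulfonyl group would be needed to separate the two. On these data alone, how a free amine on that chain carbon would behave also stays open.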